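The source may hold more compounds than are shown below. What is called first, only, known or untested is meant among the compounds shown, and "the series" means these compounds.

Measured compounds:
- compound 1, `CCOC(=O)/C=C/c1ccc2c(c1)C(=O)C(=O)N2Cc1ccc(OC)cc1`: 30 nM
- compound 2, `CCOC(=O)/C=C/c1ccc2c(c1)C(=O)C(=O)N2Cc1ccc(Br)cc1`: 70 nM
- compound 3, `COc1ccc(CN2C(=O)C(=O)c3cc(/C=C/C(=O)OCCO)ccc32)cc1`: 500 nM

All three were tested in a functional assay on Jurkat cells (Homo sapiens) for antiproliferative activity, read by MTT assay, with a stated time of 48 h; a lower number here means a stronger inhibitor, a higher number a weaker inhibitor. Compound 1 and compound 2 share one core and differ at a single point: bromo in place of methoxy on an aromatic carbon. That swap gave a 2.3-fold higher number from compound 1 to compound 2 (0.37 log units; beyond the scatter). Compound 3 carries the core of compound 1 with a further alteration on the ester chain, (hydroxy in place of hydrogen on a saturated chain carbon, two bonds along the chain from an oxygen next to a carbonyl group), and this alone gave a 17-fold higher number from compound 1 to compound 3 (1.22 log units; beyond the scatter), leaving compound 3 with the highest number of the three.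

Compound 4, `O=C(/C=C/c1ccc2c(c1)C(=O)C(=O)N2Cc1ccc(Br)cc1)OCCO`, has not yet been measured. It stands to compound 3 exactly as compound 2 stands to compound 1: the difference is bromo in place of methoxy on an aromatic carbon, and the place of the change is described in the same words for both pairs, so it is the same change made on a core that differs only by the hydroxy group on the chain.

With a single earlier example of this swap, the expectation for compound 4 rests on that one step: in this assay compound 4 is expected to give 1100 nM, because the same change gave a 2.3-fold higher number from compound 1 to compound 2 (0.37 log units; beyond the scatter). Among the compounds with values here, the step from compound 3 to compound 4 is thus estimated as a 2.2-fold higher number from compound 3 to compound 4 (0.34 log units; beyond the scatter), with a likely range from 400 nM to 3000 nM, the width reflecting that only one prior instance of the change is available and that it was made on a differently substituted chain.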

Compound 4, half-maximal inhibitory concentration: 400 nM
Compound 4: the middle estimate sits 2.8-fold (0.44 log units) above what was measured, within the range that was stated.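

In this assay, bromo in place of methoxy on the core carrying the hydroxy group on the ester chain gave a 1.3-fold lower number from compound 3 to compound 4 (0.10 log units; within the scatter) and so lacked the clear step seen on the core of compound 1, which means the size of this swap did not carry from one core to the other:  the same change on two cores in this assay, a 2.3-fold higher number (0.37 log units; beyond the scatter) from compound 1 to compound 2 and a 1.3-fold lower number (0.10 log units; within the scatter) from compound 3 to compound 4, 2.9-fold (0.46 log units) apart, beyond the scatter of two such steps

Read the other way, the hydroxy group gave a higher number on both cores, with a 5.7-fold higher number from compound 2 to compound 4 (0.76 log units; beyond the scatter) on the bromo core, so the direction held across this pair while the size did not:  the same change on two cores in this assay, a 17-fold higher number (1.22 log units; beyond the scatter) from compound 1 to compound 3 and a 5.7-fold higher number (0.76 log units; beyond the scatter) from compound 2 to compound 4, 2.9-fold (0.46 log units) apart, beyond the scatter of two such steps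

These two gaps are one comparison of the same four compounds seen from two sides, so they show that the two changes do not simply add up here, but they do not show why, and one pair of cores cannot say how this would play out elsewhere in the series.

As far as these compounds go, whether a chloro or a methyl group in the same place on the benzyl ring would behave like bromo or like methoxy remains open. So does whether the dependence between the two sites would persist with a longer chain, an amine or a carboxylic acid on the ester in place of the hydroxy group.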